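The source may report more compounds than this note shows. Statements on the series, on what has been measured and on what is new or still open speak of the compounds shown alone.

Compound 1, `COc1ccc(-c2cc(-c3cccn3C)c(C#N)c(=O)[nH]2)cc1OC`: > 100000 nM
Compound 2, `Cn1cccc1-c1cc(-c2cccs2)[nH]c(=O)c1C#N`: 69200 nM
Compound 3, `CC1CCCc2c1[nH]c(=O)c(C#N)c2-c1cccn1C`: > 100000 nM

Three compounds built on a shared core were tested in a functional assay on NCI-H226 cells (Homo sapiens) for inhibition, read by sulforhodamine B assay, with a stated time of 48 h; a lower number here means a stronger inhibitor of growth, a higher number a weaker inhibitor of growth. For compound 1 the assay gives only a limit, > 100000 nM. For compound 3 the assay likewise gives only a limit, > 100000 nM. Among the compounds with values here, compound 2 is the single compound with a number, 69200 nM, and so it stands alone as the one measured value. Two of the three results are the limit of > 100000 nM in this assay, at which 2 of the 3 values shown sit.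

Compound 4, `Cn1cccc1-c1cc(-c2ccccc2)[nH]c(=O)c1C#N`, has not yet been measured. It differs from compound 2 by phenyl in place of thiophen-2-yl on an aromatic carbon. Within the data shown here, no measured step of this kind exists among the three compounds, so there is nothing to copy from. In this assay the expected step is small, none beyond the scatter, with a slight lean toward weaker growth inhibition given (the limit of > 100000 nM in this assay, at which 2 of the 3 values shown sit). Compound 4 is therefore estimated at 90000 nM, with a range from 30000 nM to 300000 nM. The expected step, a 1.3-fold higher number from compound 2 to compound 4 (0.11 log units; within the scatter), is modest.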

Compound 4, concentration for 50% growth inhibition: > 100000 nM
Compound 4 ended at the assay's limit; the forecaster's own chance of this, stated with the estimate: 45%; middle value at least 1.1-fold (0.04 log units) from the limit.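

Within the data shown here, at the aromatic carbon next to the ring nitrogen, phenyl in place of thiophen-2-yl gives the first step that can be read in this assay: an at least 1.4-fold higher number from compound 2 to compound 4 (0.15 log units; that floor lies within the scatter). Compound 4 gives > 100000 nM, which is a limit of the assay and not a number. As far as these compounds go, the change therefore brings no measurable gain in growth inhibition, and its true size stays unknown, with only a floor that can be read: the limit of > 100000 nM in this assay, at which 3 of the 4 values shown sit.

From the compounds shown here alone, whether a furan-2-yl ring or an aminomethyl group on this carbon would give a clearly lower number than compound 2 at 69200 nM remains open. Also open, going by these compounds, is what a carboxylic acid in place of the cyano group would do to growth inhibition with thiophen-2-yl kept in place.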